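The compounds below may be only part of what the source reports. "The series", "measured", "known", "first", "only" and "open" are said of these compounds alone.

Compound 1 `COc1cccc(/C=C/C(=O)c2sc(Nc3ccc(Cl)c(Cl)c3)nc2C)c1`: 8350 nM in a functional assay on BGC-823 cells (Homo sapiens) for cytotoxicity, read by MTT assay; on this read-out higher numbers stand for weaker inhibition and lower numbers for stronger inhibition
Compound 2 `Cc1ccccc1Nc1nc(C)c(C(=O)/C=C/c2ccccc2Cl)s1`: > 25000 nM
Compound 3 `Cc1ccccc1Nc1nc(C)c(C(=O)/C=C/c2ccccc2)s1`: > 25000 nM

Compound 3 stands only at a limit of this assay, not at a number. Compound 2 also sits at that limit (the limit of > 25000 nM in this assay, at which 2 of the 3 values shown sit). The step that the two limits leave unreadable from compound 2 to compound 3 therefore cannot be read. Compound 1 alone gives a number in this assay. Compound 4 `Cc1nc(Nc2ccc(Cl)c(Cl)c2)sc1C(=O)/C=C/c1ccccc1` differs from compound 3 by 3,4-dichlorophenyl in place of 2-methylphenyl on a nitrogen on an aromatic ring. Going by the values given here, no measured step covers this change, and the only recorded step, a step that the two limits leave unreadable from compound 2 to compound 3, is unreadable. Among the compounds with values here, compound 4 shares the 3,4-dichlorophenyl of compound 1, which gives 8350 nM, the sole guide here. Compound 4 is thus expected near 10000 nM, between 3000 nM and 30000 nM, an expected step of an at least 2.5-fold lower number from compound 3 to compound 4 (0.39 log units; beyond the scatter), with a limit still quite possible.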

Compound 4, half-maximal inhibitory concentration: 10600 nM
The estimate for compound 4 lay 1.1-fold (0.03 log units) below the measured number; the measured number falls inside the stated range.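

In this assay, going by these compounds alone, 3,4-dichlorophenyl in place of 2-methylphenyl on the nitrogen gives an at least 2.3-fold lower number from compound 3 to compound 4 (0.37 log units; beyond the scatter), the first readable step at this position. As far as these compounds go, its full size stays unknown because compound 3 stands at a limit, not at a number: the limit of > 25000 nM in this assay, at which 2 of the 4 values shown sit. With 3,4-dichlorophenyl kept, loss of the methoxy gives a 1.3-fold higher number from compound 1 to compound 4 (0.10 log units; within the scatter), so the methoxy makes no readable difference here.

The compounds shown leave open whether one chlorine alone would suffice, and how an amine or a carboxylic acid on that phenyl would read.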